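Acid dissociation across a diamine-linked aromatic series

The compounds below may be only part of what the source reports. "The series", "measured", "known", "first", "only" and "open" are said of these compounds alone.

Measured so far:
compound 1 `COc1ccc(F)cc1CNCCCNc1ccnc2cc(CCc3ccccc3)ccc12` gives 9.47 in a physicochemical assay for acid dissociation
compound 2 `Cc1cc(C)cc(Cc2ccc3c(NCCCNCc4ccco4)ccnc3c2)c1` gives 9.47 in this assay
compound 3 `c1ccc(CCc2ccc3c(NCCCNCc4ccco4)ccnc3c2)cc1` gives 9.47 in this assay

Compound 1 stands level with compound 2 and compound 3 at the digits shown; all three values lie within the scatter of one another, so no order can be drawn among them. Going by the values given here, the two steps measured so far, no change at the digits printed from compound 1 to compound 3 (within the scatter) and no change at the digits printed from compound 2 to compound 3 (within the scatter), each stayed within the scatter, the first changing the group on the chain carbon bound to the amine nitrogen, the second changing the group carried by the saturated chain carbon bound to an aromatic carbon of the shared core.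

Compound 4 `COc1ccc(F)cc1CNCCCNc1ccnc2cc(Oc3ccc(F)cc3)ccc12` is not yet measured. Relative to compound 1 the change is 4-fluorophenoxy in place of phenethyl on an aromatic carbon. The step from compound 2 to compound 3 is the one that bears most directly on it, since it also alters the group hanging from the shared core, and it showed no change. On that basis the expected step of no change at the digits printed from compound 1 to compound 4 (within the scatter) is none beyond the scatter. Compound 4 is therefore expected to give about 9.47, between 9.1 and 9.8.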

Compound 4, acid dissociation constant: 9.28
Compound 4: middle estimate off by 0.19 log units, on the high side; the range from low to high includes it.
By their numbers in this assay, from the lowest: compounds 4, 1, 2 and 3 (each within the scatter of the next).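

Replacing phenethyl with 4-fluorophenoxy on this aromatic carbon of the shared core gives a number 0.19 log units lower from compound 1 to compound 4 (within the scatter) in this assay. The earlier steps shown here changed groups on saturated chain carbons, whereas this one changes the group directly on the aromatic carbon, meta to a fused ring and para to a fused ring. An all-carbon group gives way here to one carrying oxygen and fluorine, with the reading still within the scatter, and no supporting measurement bears on this step.

Still open, on these data alone, is whether an amine or a carboxylic acid on the same aromatic carbon would also stay within the scatter in this assay. As far as these compounds go, a longer chain in the diamine part of the series remains equally open.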